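The source may hold more compounds than are shown below. What is called first, only, known or untested is meant among the compounds shown, and "the series" means these compounds.

Of the compounds shown here, two have so far been tested in a toxicity assay on THP-1 cells (Homo sapiens) for inhibition; on this read-out higher numbers stand for lower toxicity in this test and lower numbers for higher toxicity in this test. Compound 1 `Cn1c(-c2ccccc2)cnc1NC(=O)c1ccccc1` gives only a limit of the assay, > 100000 nM. Compound 2 `COc1ccc(-c2cnc(NC(=O)c3ccco3)n2C)cc1` likewise gives only a limit of the assay, > 100000 nM. Compound 2 thus stands at the limit at which both known values sit (the limit of > 100000 nM in this assay, at which 2 of the 2 values shown sit), and no numbered value is available for either compound. Compound 3 `COc1ccc(C(=O)Nc2ncc(-c3ccc(OC)cc3)n2C)cc1` has not yet been measured. It differs from compound 2 in one place (4-methoxyphenyl in place of furan-2-yl on a carbonyl carbon), the incoming 4-methoxyphenyl sitting on a carbonyl carbon whose other neighbour is an amide-type nitrogen. Among the compounds with values here, no step between measured compounds exists, so the data give no measure of what such a change does. The step of a number no higher from compound 2 to compound 3 (the limit leaves the size open) is expected to stay within the usual scatter, with no direction favoured. Compound 3 is expected to give about 100000 nM, within 50000 nM to 200000 nM, and most probably to be reported again only as a limit.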

Compound 3, half-maximal cytotoxic concentration: > 100000 nM
Compound 3: a limit, no number; the forecaster's own chance of this, stated with the estimate: 80%; the middle value sits exactly at the limit.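

No step can be read between compound 2 and compound 3 in this assay, since compound 3, like compound 2, gives only a limit and no number. All compounds shown sit at one value: the limit of > 100000 nM in this assay, at which 3 of the 3 values shown sit.

What the compounds shown leave open is how any of them would rank on a numbered value, and what replacing furan-2-yl with 4-methoxyphenyl does to the read-out.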